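From Ethyl Ester to Free Acid: Compound 3

The source may report more compounds than this note shows. Statements on the series, on what has been measured and on what is new or still open speak of the compounds shown alone.

Compound 1 `CCOC(=O)/C=C/c1cccc(OC)c1OCc1nc(C)c(C)nc1C`: 3040000 nM
Compound 2 `CCOC(=O)/C=C/c1cc(Br)c(OCc2nc(C)c(C)nc2C)c(Br)c1`: 155000 nM

In a functional assay on ECV-304 cells (Homo sapiens) for cytotoxicity, read by MTT assay, with stated times of 24 h and 12 h (a lower number here means that less compound is needed, a higher number that more compound is needed for the effect), compound 1 stands highest of the two at 3040000 nM, and compound 2 gives 155000 nM. The number of compound 2 is the lower one, and the gap between the two lies beyond the scatter. Compound 3 `COc1cccc(/C=C/C(=O)O)c1OCc1nc(C)c(C)nc1C` differs from compound 1 in one place, hydrogen in place of ethyl on an oxygen next to a carbonyl group. Going by the values given here, no measured pair shows this change, so the expectation is uncertain. With compound 1 at the top of the measured values at 3040000 nM, a moderate move to a lower number is expected. The estimated step is a 5.1-fold lower number from compound 1 to compound 3 (0.70 log units; beyond the scatter). Compound 3 is expected at 600000 nM, with an estimated range from 80000 nM to 3500000 nM.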

Compound 3, half-maximal effective concentration: 3590000 nM
The estimate for compound 3 lay 6.0-fold (0.78 log units) below the measured number, and the stated range ends below it.
By their numbers in this assay, from the lowest: compound 2; then compounds 1 and 3 (each within the scatter of the next).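

Exchanging ethyl for hydrogen on an oxygen next to a carbonyl group, ethoxycarbonyl to carboxy, gives a 1.2-fold higher number from compound 1 to compound 3 (0.07 log units; within the scatter) in this assay and so leaves the number within the scatter. At this position, on the core of compound 1, the ethyl group can therefore go without a change that this read-out can resolve. No available evidence explains this result. 

Going by these compounds, whether the same exchange behaves alike on compound 2 remains open. So does the outcome with a primary amide or a longer chain on that oxygen.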